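The source may report more compounds than this note shows. Statements on the series, on what has been measured and on what is new or still open speak of the compounds shown alone.

Compound 1 `Nc1cc(N)c2nc(-c3ccccc3)c(Oc3ccc(Cl)c(Cl)c3)nc2c1` is the nearest measured relative of the compound to be estimated. In a functional assay on K562 cells (Homo sapiens) for inhibition, read by sulforhodamine B assay, with a stated time of 48 h (a higher number here means a weaker inhibitor of growth, a lower number a stronger inhibitor of growth), compound 1 gives < 100000 nM, which is a limit of the assay and not a number. Among the measured compounds shown here, compound 2 `CCOC(=O)[C@H](CCC(=O)O)NC(=O)c1ccc(CNc2nc3cc(N)cc(N)c3nc2-c2ccccc2)cc1` is the only other measured member. In this assay compound 2 gives < 100000 nM, again a limit. Both values sit at the limit of < 100000 nM in this assay, at which 2 of the 2 values shown sit, so where compound 1 truly stands on the numbers cannot be read off. Compound 3 `Nc1cc(N)c2nc(-c3ccccc3)c(Sc3ccc(F)cc3)nc2c1` carries (4-fluorophenyl)sulfanyl in place of 3,4-dichlorophenoxy on an aromatic carbon. For the measured compounds named here, with no measured step to lean on, the step from compound 1 to compound 3 is expected to be a step that the limit leaves unreadable from compound 1 to compound 3, in no firm direction. Compound 3 is estimated at 20000 nM, in a range from 3000 nM to 90000 nM.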

Compound 3, concentration for total growth inhibition: 38900 nM
For compound 3 the middle estimate is 1.9-fold (0.29 log units) below the measured one; measured number inside the range.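

No step can be read between compound 1 and compound 3, because the result for compound 1 is a limit of the assay and not a number: the limit of < 100000 nM in this assay, at which 2 of the 3 values shown sit. On these data alone, what the change from 3,4-dichlorophenoxy to (4-fluorophenyl)sulfanyl does in this assay stays open.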